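The source may hold more compounds than are shown below. What is called first, only, known or untested is meant among the compounds shown, and "the series" means these compounds.

Compound 1 `CCCCCCCCCCCCCCCCCC(=O)CCCCCOP(=O)(O)OC[C@H](N)C(=O)O`: > 10000 nM (a limit, not a number)
Compound 2 `CCCCCCCCCCCCCCCCCC(=O)NC[C@@H](O)COP(=O)(O)OC[C@H](N)C(=O)O`: 5000 nM

Both readings come from a functional assay on cells (Mast cell, Rattus norvegicus, strain Wistar) for activation, read by fluorescence, with a stated time of 15 min; on this read-out higher numbers stand for an effect only at larger amounts of compound and lower numbers for an effect already at smaller amounts. Compound 1 gives > 10000 nM there, and this is a limit of the assay. For the measured compounds named here, compound 2, at 5000 nM, therefore holds the only actual number so far, and the other reading is not a number it can be ranked against.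

Compound 3 `CCCCCCCCCCCCCCCCCC(=O)N(C)C[C@@H](O)COP(=O)(O)OC[C@H](N)C(=O)O` differs from compound 2 in a single place: methyl in place of hydrogen on an amide-type nitrogen. Going by the values given here, the series has no measured step that sizes this change, so the expectation rests on judgement. A modest move toward higher numbers in this assay is expected, perhaps not far beyond the usual scatter, and the estimated change is a 1.8-fold higher number from compound 2 to compound 3 (0.26 log units; within the scatter). A result for compound 3 reported only as a limit would be no surprise. For compound 3 the expected value is 9000 nM, with an estimated range of 3000 nM to 30000 nM.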

Compound 3, half-maximal effective concentration: 10000 nM
Beside the measured number, compound 3's estimate is 1.1-fold (0.05 log units) below it, and the stated range covers the measured number.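

In this assay, for the compounds shown here, the only step measured at this place reads a 2.0-fold higher number from compound 2 to compound 3 (0.30 log units; within the scatter), so methyl in place of hydrogen on an amide-type nitrogen gives no difference that can be separated from the usual scatter. Going by these compounds alone, this is the first view of the series at this nitrogen, and it shows that, in this pair, the reading does not depend on keeping the amide hydrogen beyond what the scatter can resolve. The value of compound 1 is a limit, not a number, so no step to it can be read: the limit of > 10000 nM in this assay, at which 1 of the 3 values shown sits.

Still open, on these data alone, is whether ethyl or a longer chain on the same amide-type nitrogen would read apart from methyl by more than the scatter in this assay, since a single methyl step says nothing about the size that this place tolerates. Equally open, as far as these compounds go, is how the pair would respond to a shorter or longer saturated chain on the carbonyl carbon, or to an ester in place of the carboxylic acid of the shared core.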